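A few compounds are considered here, and "the series" means these few. Any claim that something is new, unique, unknown or untested is made for them only; others in the source may bear on it.

Of the compounds shown here, two of this set have been measured in a functional assay on EL4 cells (Mus musculus) for antiproliferative activity, read by sulforhodamine B assay, with a stated time of 48 h; on this read-out lower numbers stand for stronger inhibition and higher numbers for weaker inhibition. Compound 1, `C[C@@]12CCCC[C@H]1CC=C(O)C2=O`, gives 114000 nM in this assay. Compound 2, `CC1(C)[C@@H]2CC3=NCC(=O)O[C@@]3(C)[C@H]1C2`, gives 19000 nM in this assay, the lowest of the two numbers, and its gap to compound 1 lies beyond the usual scatter, so compound 2 is the stronger inhibitor of the pair. For the measured compounds named here, no two measured compounds differ in a single place, so no step between them can be read.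

Compound 3, `CC1(C)[C@H]2CC3=NCC(=O)O[C@]3(C)[C@@H]1C2`, has not yet been measured. It differs from compound 2 as follows: the two compounds have the same atoms and bonds and differ only in configuration as drawn: 3 of 3 stereo elements differ (all stereocentres are inverted: mirror images); a stereocentre at a saturated ring carbon is drawn S in compound 2 and R in compound 3; a stereocentre at a saturated ring carbon is drawn S in compound 2 and R in compound 3; a stereocentre at a saturated ring carbon is drawn S in compound 2 and R in compound 3. Going by the values given here, nothing among the measured compounds shows how a mirror image behaves in this assay, so the direction of the change is open. The step expected from compound 2 to compound 3 in this assay is a 1.6-fold higher number from compound 2 to compound 3 (0.20 log units; within the scatter), which is taken to lie within the scatter, with a wide range on either side. Compound 3 is therefore estimated to give 30000 nM in this assay, with a range from 8000 nM to 120000 nM.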

Compound 3, half-maximal inhibitory concentration: > 300000 nM
Compound 3 was reported as a limit (the forecaster's own chance of this, stated with the estimate: 10%); middle value at least 10-fold (1.00 log units) from the limit.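

For the compounds shown here, the first step that can be read in this assay is an at least 15-fold higher number from compound 2 to compound 3 (1.19 log units; beyond the scatter), and it is a large one, beyond the scatter: inverting all three stereocentres, with no atom or bond changed, is enough to separate the two mirror images clearly, which shows that configuration matters on this core. Compound 3 gives > 300000 nM, which is a limit and not a number, so the step gives only the smallest gap the data allow and its full size stays unknown: the limit of > 300000 nM in this assay, at which 1 of the 3 values shown sits. The gap can be ascribed to configuration alone, because no other structural change separates the pair: the fact that compounds 2 and 3 differ only in the configuration as drawn

The compounds shown leave open whether this preference for one mirror image would persist with another group on the core of compound 2, such as an amine, a carboxylic acid or a longer chain, and whether inverting a single stereocentre rather than all three would matter as much. They also do not place compound 1 relative to this pair in terms of structure, since it differs from both in more than one place and those steps cannot be read.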